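The source may report more compounds than this note shows. Statements on the series, on what has been measured and on what is new or still open speak of the compounds shown alone.

Measured compounds:
compound 1, `CC(C)C[C@H](N)c1cc(Cl)ccc1N1CCN(C(=O)C2NCCC2c2ccc(Cl)cc2)CC1`: 96 nM
compound 2, `CCC(=O)N1CC[C@H](c2ccc(Cl)cc2)[C@H]1C(=O)N1CCN(c2ccc(C)cc2[C@@H](N)C(C)C)CC1`: 62 nM

Of the compounds shown here, two have been measured in an assay on HEK293 cells for displacement of a labelled ligand from Melanocortin receptor 4 (Homo sapiens); on this read-out lower numbers stand for stronger inhibition and higher numbers for weaker inhibition. In this assay compound 1 gives 96 nM, and compound 2 gives 62 nM; the two numbers lie within the usual scatter of each other, so nothing separates them. Compound 1 shares its core with the unmeasured compound 3, `CC(C)C[C@H](N)c1cc(C(F)(F)F)ccc1N1CCN(C(=O)C2NCCC2c2ccc(Cl)cc2)CC1`. The difference between them is trifluoromethyl in place of chloro on an aromatic carbon. Among the compounds with values here, no measured pair shows this exchange, so its effect in this assay is unknown here; with no comparable step to lean on, the expectation is a step no larger than the scatter, in either direction. Compound 3 is therefore expected to give 100 nM in this assay, within a range of 35 nM to 290 nM. That estimate means a step of a 1.0-fold higher number from compound 1 to compound 3 (0.02 log units; within the scatter), expected to stay within the usual scatter.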

Compound 3, inhibition constant: 98 nM
Beside the measured number, compound 3's estimate is 1.0-fold (0.01 log units) above it; the range from low to high includes it.
By their numbers in this assay, from the lowest: compounds 2, 1 and 3 (each within the scatter of the next).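

In this assay, within the data shown here, trifluoromethyl in place of chloro on an aromatic carbon, meta to a 1-amino-3-methylbutyl group and para to a large group, gives a 1.0-fold higher number from compound 1 to compound 3 (0.01 log units; within the scatter) and provides the first reading of a change at this position alone. Compounds 1 and 2 differ in more than one place, so they could not show this. At this position on the shared core, the larger substituent by heavy-atom count is therefore tolerated in this read-out, with no difference from chloro beyond the scatter. No supporting data bear on why the two groups read alike.

From the compounds shown here alone, it remains open whether fluoro, methoxy, a nitrile or an amine at this position would also stay within the scatter. Going by these compounds, it is also open whether the exchange would read the same with a chain other than the 1-amino-3-methylbutyl group.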